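This account rests on a few compounds, and the source may have more. Where it says the series, first, only, none or still open, it means among the compounds named here.

Measured compounds and their numbers:

compound 1, `CC1=C(C(=O)Nc2ccc(F)cc2)C(c2ccc([N+](=O)[O-])cc2)N=C(SCc2ccccc2Cl)N1`, 8.8%
compound 2, `CC1=C(C(=O)Nc2ccc(Br)cc2)C(c2ccc(Cl)cc2Cl)N=C(SCc2ccccc2)N1`, 10.3%
compound 3, `COc1ccc(C2N=C(SCc3ccccc3)NC(C)=C2C(=O)Nc2ccc(Br)cc2)cc1`, 8.2%

In a functional assay on the whole organism (artery, strain albino) with Rattus norvegicus as the target, with a stated time of 120 min, at a dose of 10 mg/kg by the oral route (on this read-out lower numbers stand for less inhibition and higher numbers for more inhibition at the one dose given (going by the name of the read-out)), compound 3 gives 8.2%. That number sits within the scatter of both compound 1 with 8.8% and compound 2 with 10.3%, so the three measured compounds cannot be told apart on this read-out. For the measured compounds named here, the only single-place step among them, a number 2.1 percentage points lower from compound 2 to compound 3 (within the scatter), lies within the scatter as well, and it concerns the group on the saturated ring carbon, not the benzylsulfanyl side of the core.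

Compound 4, `COc1ccc(C2N=C(SCc3ccc(Cl)cc3)NC(C)=C2C(=O)Nc2ccc(Br)cc2)cc1`, has not yet been measured in this assay. It differs from compound 3 by chloro in place of hydrogen on an aromatic carbon, that is, benzylsulfanyl becoming (4-chlorobenzyl)sulfanyl. Going by the values given here, no measured step touches this part of the shared core: compound 1 carries a different benzyl group, but it also differs from compound 3 in several other places at once, so nothing can be read from it about a single change here. The expectation therefore rests on the flatness of the numbers seen so far. Compound 4 is expected to stay where compound 3 stands, with a step of a number 0.8 percentage points higher from compound 3 to compound 4 (within the scatter) that does not reach beyond the scatter. The estimate for compound 4 in this assay is 9%, with a range from 1% to 19%.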

Compound 4, a percentage reported as inhibition, in the whole organism at one dose (the size of the read-out at that dose, not a potency): 16.5%
For compound 4 the middle estimate is 7.5 percentage points below the measured one; low and high end bracket the measured number.
By their numbers in this assay, from the lowest: compounds 3, 1, 2 and 4 (each within the scatter of the next).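

Going from benzylsulfanyl to (4-chlorobenzyl)sulfanyl gives the first single-place step on this side of the shared core, and in this assay it reads a number 8.3 percentage points higher from compound 3 to compound 4 (within the scatter). Chloro in place of hydrogen on this aromatic carbon, para to a large group, therefore does not separate the two compounds on this read-out, although the earlier compounds could say nothing about this change at all. Nothing available bears on what lies behind this step.

The compounds shown leave open how a nitrile, an amine or a carboxylic acid would read out at this same place on the benzyl ring, and whether any such group would give a step beyond the scatter. They also leave open whether chloro in place of hydrogen here would give a similar step when the saturated ring carbon carries a group other than 4-methoxyphenyl, or when the amide carries something other than the bromophenyl ring of compound 3 and compound 4.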